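The compounds below may be only part of what the source reports. "The series", "measured", "known", "first", "only" and "open" are said of these compounds alone.

Measured in an ADME assay on HEK-293T cells (Homo sapiens) for cytotoxicity, read by luminescence, with a stated time of 24 h; on this read-out lower numbers stand for higher toxicity in this test and higher numbers for lower toxicity in this test:
- compound 1 `CCCNC(=O)C1CCN(C(=O)c2cc3sc(C(C)=O)cc3n2Cc2ccc(OC)cc2)CC1`: > 100000 nM (a limit of the assay, not a number)
- compound 2 `CCCNC(=O)C1CCN(C(=O)c2cc3sc(CNC(C)c4ccccc4)cc3n2Cc2ccc(OC)cc2)CC1`: 33900 nM

Going by the values given here, compound 2 gives 33900 nM, the only true number so far in this assay. The other reading is a limit, (the limit of > 100000 nM in this assay, at which 1 of the 2 values shown sits).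

Compound 3 `CCCNC(=O)C1CCN(C(=O)c2cc3sc(C)cc3n2Cc2ccc(OC)cc2)CC1` is still to be measured. Its difference from compound 2 is hydrogen in place of (1-phenylethyl)amino on a saturated chain carbon bound to an aromatic carbon. In words, this is hydrogen in place of (1-phenylethyl)amino on a saturated chain carbon bound to an aromatic carbon, or ((1-phenylethyl)amino)methyl to methyl when cut one bond further out.

Among the compounds with values here, one measured step bears on this change: an at least 2.9-fold lower number from compound 1 to compound 2 (0.46 log units; beyond the scatter). That step, at least modest and beyond the scatter, brought in ((1-phenylethyl)amino)methyl in place of acetyl, and compound 3 loses the amine part of that group. Within the data shown here, a move back to higher numbers of similar size is therefore expected, although no measured compound carries methyl at this place. The expected step is a 2.5-fold higher number from compound 2 to compound 3 (0.40 log units; beyond the scatter), and a reading at the limit of the assay would be no surprise. For compound 3 the estimated value is 85000 nM, with an expected range of 35000 nM to 150000 nM.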

Compound 3, half-maximal cytotoxic concentration: 36300 nM
The estimate for compound 3 lay 2.3-fold (0.37 log units) above the measured number; low and high end bracket the measured number.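

In this assay, taking off (1-phenylethyl)amino on a saturated chain carbon bound to an aromatic carbon leaves the two readings within the scatter of each other (a 1.1-fold higher number from compound 2 to compound 3 (0.03 log units; within the scatter)), so the amine part with its phenyl ring adds nothing detectable to the reading of compound 2. Methyl in place of acetyl on an aromatic carbon gives an at least 2.7-fold lower number from compound 1 to compound 3 (0.44 log units; beyond the scatter), and the larger amine-bearing group at the same place gives an at least 2.9-fold lower number from compound 1 to compound 2 (0.46 log units; beyond the scatter); both steps lie beyond the scatter, so in these three compounds the lower number goes with the loss of acetyl and not with what replaces it. The reading of compound 1 is a limit of the assay and not a number, so the true size of both steps out of it stays open: the limit of > 100000 nM in this assay, at which 1 of the 3 values shown sits.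

Open, as far as these compounds go, is whether a carboxylic acid or a primary aminomethyl group at this place would read with compound 2 and compound 3 or with compound 1 in this assay. Also open, from the compounds shown here alone, is whether a ketone with a longer chain than acetyl would stay at the limit seen for compound 1.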